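The source may hold more compounds than are shown below. What is called first, only, known or untested is meant among the compounds shown, and "the series" means these compounds.

Series notes. Compound 1 `COC(=O)N(C)C(C)C#CCN1CCCC1` and compound 2 `COC(=O)N(C)C(C)C#CCn1ccnc1` share a core and differ only in the group on a saturated chain carbon bound to a triple-bonded carbon. In a functional assay on the whole organism for agonist activity, with Mus musculus as the target (a higher number here means that more compound is needed for the effect, a lower number that less compound is needed), compound 1 gives 9.7 mg/kg, and compound 2 gives 6.6 mg/kg. The change between the two is 1H-imidazol-1-yl in place of pyrrolidin-1-yl on a saturated chain carbon bound to a triple-bonded carbon, and the step it made is a 1.5-fold lower number from compound 1 to compound 2 (0.17 log units; within the scatter). Compound 3 `CCOC(=O)N(C)CC#CCN1CCCC1` has the same atoms as compound 1 joined differently; the difference between the two cores is not broken down here. In this assay compound 3 gives 66 mg/kg, the highest number of the three measured; compound 1 stands nearest to it and compound 2 furthest, both gaps beyond the scatter. Compound 4 `CCOC(=O)N(C)CC#CCn1ccnc1` is not yet measured in this assay. It differs from compound 3 by 1H-imidazol-1-yl in place of pyrrolidin-1-yl on a saturated chain carbon bound to a triple-bonded carbon, the same change seen from compound 1 to compound 2; among the compounds shown this change occurs twice in all. For the measured compounds named here, the step from compound 3 to compound 4 in this assay is expected to be about the size of the earlier one, because the only measured instance of this change is a 1.5-fold lower number from compound 1 to compound 2 (0.17 log units; within the scatter), which lies within the scatter; a single pair gives no ground to expect anything larger. The expected step is a 1.5-fold lower number from compound 3 to compound 4 (0.17 log units; within the scatter). Compound 4 is therefore estimated at 45 mg/kg, with a range from 20 mg/kg to 100 mg/kg, kept wide since the change has been measured only once.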

Compound 4, dose for half-maximal effect: > 100 mg/kg
Compound 4: a limit, no number; the forecaster's own chance of this, stated with the estimate: 5%; middle value at least 2.2-fold (0.34 log units) from the limit.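

In this assay compound 4 gives > 100 mg/kg, which is a limit of the assay and not a number. The new step, an at least 1.5-fold higher number from compound 3 to compound 4 (0.18 log units; that floor lies within the scatter), can therefore be read only as a floor, and it stands against the earlier instance of the same change as follows: the same change on two cores in this assay, a 1.5-fold lower number (0.17 log units; within the scatter) from compound 1 to compound 2 and an at least 1.5-fold higher number (0.18 log units; that floor lies within the scatter) from compound 3 to compound 4; the limit leaves it open whether they differ This shows that replacing pyrrolidin-1-yl with 1H-imidazol-1-yl on a saturated chain carbon bound to a triple-bonded carbon has now been tested on two cores, with neither step shown to lie beyond the scatter; it does not show that the change transfers from one core to the other, nor that its effect depends on the core.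

The compounds shown leave open how far compound 4 lies past its limit, and so whether the true step on this core is small or large. They also leave open how piperidin-1-yl or dimethylamino on a saturated chain carbon bound to a triple-bonded carbon would compare with pyrrolidin-1-yl and 1H-imidazol-1-yl on either core.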